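The source may hold more compounds than are shown below. What is called first, only, known or untested is meant among the compounds shown, and "the series" means these compounds.

Measured so far in an assay on isolated protein for inhibition of Aromatase (Homo sapiens), read by fluorescence, with stated times of 10 min and 60 min; on this read-out lower numbers stand for stronger inhibition and higher numbers for weaker inhibition:
compound 1, `CCCOc1ccc(C(=O)c2cccc(Cn3ccnc3)c2)cc1`: 2 nM
compound 2, `O=C(c1ccc(O)cc1)c1cccc(Cn2ccnc2)c1`: 13 nM

Compound 2 stands highest of the two numbers; the nearest is compound 1, reached by the step of a 6.5-fold higher number from compound 1 to compound 2 (0.81 log units; beyond the scatter). Compound 3, `CCC#CCOc1ccc(C(=O)c2cccc(Cn3ccnc3)c2)cc1`, differs from compound 2 by pent-2-yn-1-yl in place of hydrogen on an oxygen on an aromatic ring. Among the compounds with values here, the only step that bears on this is the one from compound 1 to compound 2, which put a hydrogen in place of an alkyl chain on the same oxygen and raised the number beyond the scatter; the present change runs the other way with a different chain. A lower number for compound 3 is therefore expected, roughly reversing that step, a 4.3-fold lower number from compound 2 to compound 3 (0.64 log units; beyond the scatter). The estimate for compound 3 is 3 nM, with a range of 1 nM to 12 nM.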

Compound 3, half-maximal inhibitory concentration: 9 nM
For compound 3 the middle estimate is 3.0-fold (0.48 log units) below the measured one; measured number inside the range.
By their numbers in this assay, from the lowest: compound 1; then compounds 3 and 2 (each within the scatter of the next).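

In this assay, a chain on this oxygen does not by itself bring the number down: pent-2-yn-1-yl in place of hydrogen gives a 1.4-fold lower number from compound 2 to compound 3 (0.16 log units; within the scatter), whereas but-1-yn-1-yl in place of ethyl on the chain gives a 4.5-fold higher number from compound 1 to compound 3 (0.65 log units; beyond the scatter). At this position, the identity of the chain therefore matters, not only the loss of the hydroxy hydrogen. Nothing available accounts for the difference between the two chains.

Still open, going by these compounds, is whether a pentyl chain, a methyl group or a chain ending in an amine on this oxygen would read closer to compound 1 or to compound 2.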